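Compound 4: acetylazetidine on the amide side chain

The source may hold more compounds than are shown below. What is called first, only, known or untested is meant among the compounds shown, and "the series" means these compounds.

In a physicochemical assay for solubility, read by spectrophotometry, measured as kinetic solubility, at pH 8, tested at 500 uM (on this read-out higher numbers stand for higher solubility and lower numbers for lower solubility), compound 3 `CC(=O)N1CCOC(CNC(=O)c2ccncc2Nc2cc(-c3ccc4ccn(C)c4c3)c3nccnc3c2)C1` gives 268 ug/mL and compound 2 `Cn1ccc2ccc(-c3cc(Nc4cnccc4C(=O)NCC4COCCN4)cc4nccnc34)cc21` gives 239 ug/mL, a pair that cannot be told apart: a 1.1-fold higher number from compound 2 to compound 3 (0.05 log units; within the scatter). Compound 1 `CN1CCC(NC(=O)c2ccncc2Nc2cc(-c3ccc4ccn(C)c4c3)c3nccnc3c2)CC1=O` gives 48 ug/mL. Replacing its amide substituent gave modest steps: a 5.0-fold higher number from compound 1 to compound 2 (0.70 log units; beyond the scatter) and a 5.6-fold higher number from compound 1 to compound 3 (0.75 log units; beyond the scatter).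

Compound 4 `CC(=O)N1CC(CNC(=O)c2ccncc2Nc2cc(-c3ccc4ccn(C)c4c3)c3nccnc3c2)C1` differs from compound 3 as follows: 1-acetylazetidin-3-yl in place of 4-acetylmorpholin-2-yl on a saturated chain carbon bound to an amide-type nitrogen. Within the data shown here, no measured compound carries the 1-acetylazetidin-3-yl group, so the evidence is indirect. The two morpholine-bearing substituents of compound 2 and compound 3 stay within the scatter of each other, and so no step beyond the scatter is expected here: a 1.3-fold lower number from compound 3 to compound 4 (0.11 log units; within the scatter). For compound 4 the estimated value is 210 ug/mL, with an expected range of 100 ug/mL to 290 ug/mL.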

Compound 4, solubility: 252 ug/mL
For compound 4 the middle estimate is 1.2-fold (0.08 log units) below the measured one; measured number inside the range.
By their numbers in this assay, from the lowest: compound 1; then compounds 2, 4 and 3 (each within the scatter of the next).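

In this assay, 1-acetylazetidin-3-yl in place of 4-acetylmorpholin-2-yl gives a 1.1-fold lower number from compound 3 to compound 4 (0.03 log units; within the scatter), so a smaller four-membered ring lacking the ring oxygen of compound 3 still reads level with it. The same holds against the morpholin-3-yl of compound 2, with a 1.1-fold higher number from compound 2 to compound 4 (0.02 log units; within the scatter). The third ring type on this chain also stays clear of compound 1, with a 5.3-fold higher number from compound 1 to compound 4 (0.72 log units; beyond the scatter).

No measurement shown here accounts for these steps. Open, on these data alone, is how a free azetidine amine, a carboxylic acid or a longer chain between the amide nitrogen and the ring would read in this assay.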